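The compounds below may be only part of what the source reports. "The series", "measured", "known", "first", "only" and "open" are said of these compounds alone.

For the measured compounds named here, in an in vitro assay on SH-EP1 cells for displacement of a labelled ligand from Neuronal acetylcholine receptor; alpha4/beta2 (Homo sapiens) (a lower number here means a stronger inhibitor, a higher number a weaker inhibitor), compound 2 `CC(C)Oc1cncc(C2=CC3CNCC(C2)C3)c1` gives 0.26 nM, the lowest of the two numbers measured so far. Going by the values given here, the only other measured compound, compound 1 `C1=C(c2cncc(Oc3ccccc3)c2)CC2CNCC1C2`, gives 0.7 nM. These two differ in a single place, and the change shows a 2.7-fold lower number from compound 1 to compound 2 (0.43 log units; beyond the scatter). Compound 3 `COc1ccc(Oc2cncc(C3=CC4CNCC(C3)C4)c2)cc1` reverses that kind of change: 4-methoxyphenyl in place of isopropyl on an oxygen on an aromatic ring. Because a 2.7-fold lower number from compound 1 to compound 2 (0.43 log units; beyond the scatter) was a modest gain when the aromatic group left that oxygen, putting a closely related aromatic group back is expected to undo roughly that much. Compound 3 is therefore estimated at 0.7 nM, in the range 0.3 nM to 1.8 nM, an expected 2.7-fold higher number from compound 2 to compound 3 (0.43 log units; beyond the scatter).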

Compound 3, inhibition constant: 1.4 nM
For compound 3 the middle estimate is 2.0-fold (0.30 log units) below the measured one; the measured number falls inside the stated range.
By their numbers in this assay, from the lowest: compound 2; then compounds 1 and 3 (each within the scatter of the next).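

For the compounds shown here, putting 4-methoxyphenyl in place of isopropyl on this oxygen gives a step of a 5.4-fold higher number from compound 2 to compound 3 (0.73 log units; beyond the scatter) and shows that phenyl is not the only aromatic group that stands apart from isopropyl here. Methoxy in place of hydrogen on an aromatic carbon gives a 2.0-fold higher number from compound 1 to compound 3 (0.30 log units; within the scatter) and so leaves phenyl and 4-methoxyphenyl not separable by these numbers. No measurement at hand explains either step.

Still open, from the compounds shown here alone, is whether the low number belongs to isopropyl alone or would also hold for a cyclopropyl group or a longer chain on the same oxygen. Going by these compounds, it is equally open whether a nitrile in place of the methoxy would separate from phenyl.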